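Swapping 4-nitrobenzyl for 3-phenylpropyl on the shared core

The source may hold more compounds than are shown below. What is called first, only, known or untested is meant among the compounds shown, and "the series" means these compounds.

Measured in a functional assay on MGC-803 cells (Homo sapiens) for inhibition, read by MTT assay, with a stated time of 72 h; a higher number here means a weaker inhibitor, a lower number a stronger inhibitor:
- compound 1 `Cc1cc(N2CC[C@@H](C)[C@@H](N(C)c3ncnc4[nH]ccc34)C2)n2nc(SCc3ccc(Cl)cc3)nc2n1` gives 16000 nM
- compound 2 `Cc1cc(N2CC[C@@H](C)[C@@H](N(C)c3ncnc4[nH]ccc34)C2)n2nc(SCc3cc(Cl)ccc3Cl)nc2n1` gives 9850 nM
- compound 3 `Cc1cc(N2CC[C@@H](C)[C@@H](N(C)c3ncnc4[nH]ccc34)C2)n2nc(SCc3ccc([N+](=O)[O-])cc3)nc2n1` gives 27000 nM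

Compound 3 stands clearly apart from only one of the other two. The move a 1.7-fold higher number from compound 1 to compound 3 (0.23 log units; within the scatter) is small, while the move a 2.7-fold higher number from compound 2 to compound 3 (0.44 log units; beyond the scatter) is a real but modest gap.

The next structure is compound 4 `Cc1cc(N2CC[C@@H](C)[C@@H](N(C)c3ncnc4[nH]ccc34)C2)n2nc(SCCCc3ccccc3)nc2n1`, which has phenethyl in place of 4-nitrophenyl on a saturated chain carbon bound to a sulfur. Put another way, 4-nitrobenzyl becomes 3-phenylpropyl.

The three measured steps all changed this same group, and the move a 1.6-fold lower number from compound 1 to compound 2 (0.21 log units; within the scatter) was also small. None of them tests a longer chain, so the evidence is indirect. Only a small step is expected, toward a lower number, with compound 1 at 16000 nM as the nearest guide, since it also carries no nitro group. The expected change is a 1.7-fold lower number from compound 3 to compound 4 (0.23 log units; within the scatter). For compound 4 the estimate is 16000 nM, with an expected range of 7000 nM to 38000 nM.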

Compound 4, half-maximal inhibitory concentration: > 100000 nM
Compound 4: only a limit was reported; the forecaster's own chance of this, stated with the estimate: 15%; at least 6.2-fold (0.79 log units) between middle value and limit.
By their numbers in this assay, from the lowest: compounds 2, 1 and 3 (each within the scatter of the next, the first and the last beyond it). At a limit, above all of these: compound 4.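

Compound 4 gives a limit of the assay rather than a number: the limit of > 100000 nM in this assay, at which 1 of the 4 values shown sits.

For the compounds shown here, the changes among the earlier compounds moved the number modestly at most, the largest being a 2.7-fold higher number from compound 2 to compound 3 (0.44 log units; beyond the scatter), whereas the new group gives an at least 3.7-fold higher number from compound 3 to compound 4 (0.56 log units; beyond the scatter), an at least 6.2-fold higher number from compound 1 to compound 4 (0.79 log units; beyond the scatter) and an at least 10-fold higher number from compound 2 to compound 4 (1.00 log units; beyond the scatter). This position therefore tolerates changes on the ring far better, in these four compounds, than the change to 3-phenylpropyl, and compound 4 is the weakest of the set.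

That change lengthens the chain and also leaves the ring bare, so the compounds shown cannot separate the two. An unsubstituted benzyl, a 2-phenylethyl or a 3-(4-chlorophenyl)propyl group on the sulfur would tell them apart.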